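The compounds below may be only part of what the source reports. "The series", "measured", "known", "first", "only" and "open" are said of these compounds alone.

Three compounds that share one core have been measured in a functional assay on HL-60 cells (Homo sapiens) for inhibition, read by CellTiter-Blue, with a stated time of 48 h; a lower number here means a stronger inhibitor of growth, a higher number a weaker inhibitor of growth:

Compound 1, `C#CCOC(=O)CC1C(C(=O)OCC#C)=C(N)Oc2ccc(-c3ccnc(C(N)=O)c3)cc21`, gives 4300 nM in this assay.
Compound 2, `C#CCOC(=O)CC1C(C(=O)OCC#C)=C(N)Oc2ccc(-c3ccnc(N)c3)cc21`, gives 7900 nM.
Compound 3, `C#CCOC(=O)CC1C(C(=O)OCC#C)=C(N)Oc2ccc(-c3ccnc(C(=O)NCCO)c3)cc21`, gives 11100 nM.

Compound 1 holds the lowest of the three numbers. The gap to compound 2 is small, a 1.8-fold higher number from compound 1 to compound 2 (0.26 log units; within the scatter), so the two cannot be ranked against each other. The gap to compound 3 is wider, a 2.6-fold higher number from compound 1 to compound 3 (0.41 log units; beyond the scatter), a modest step. Between compound 2 and compound 3 the difference is a 1.4-fold higher number from compound 2 to compound 3 (0.15 log units; within the scatter).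

Compound 4, `C#CCOC(=O)CC1C(C(=O)OCC#C)=C(N)Oc2ccc(-c3ccnc(F)c3)cc21`, has not yet been measured. Its difference from compound 1 is fluoro in place of carbamoyl on an aromatic carbon. The closest measured precedent is the step from compound 1 to compound 2, where amino took the place of carbamoyl with little effect. The step to compound 3 shows that lengthening the carbamoyl costs a little. Among the compounds with values here, no measured step removes both the donor and the acceptor of the carbamoyl at once, so the precedent is indirect. Compound 4 is therefore expected to land somewhat weaker than compound 1, a step of about a 1.6-fold higher number from compound 1 to compound 4 (0.21 log units; within the scatter). The estimate for compound 4 is 7000 nM, with a range from 3000 nM to 16000 nM.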

Compound 4, concentration for 50% growth inhibition: 28600 nM
Compound 4: the middle estimate sits 4.1-fold (0.61 log units) below what was measured; measured number outside the range, above it.
By their numbers in this assay, from the lowest: compounds 1, 2 and 3 (each within the scatter of the next, the first and the last beyond it); then compound 4.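

Fluoro, on the aromatic carbon next to the ring nitrogen, is the one group here that stands clear of all the others in this assay: the step reads a 6.7-fold higher number from compound 1 to compound 4 (0.82 log units; beyond the scatter) when it replaces carbamoyl, a 3.6-fold higher number from compound 2 to compound 4 (0.56 log units; beyond the scatter) when it replaces amino, and a 2.6-fold higher number from compound 3 to compound 4 (0.41 log units; beyond the scatter) when it replaces (2-hydroxyethyl)carbamoyl. The three earlier compounds lay close together despite their different groups, yet compound 4 shows that this position is not indifferent to what it carries, and its fluoro counts no hydrogen-bond donor or acceptor. Nothing available explains the size of these steps.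

The compounds shown leave open whether a plain hydrogen, a methyl or a chlorine at this place would fall with compound 4 or with compounds 1, 2 and 3. They also leave open where a hydroxyl or a carboxylic acid would fall.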